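A few compounds are considered here, and "the series" means these few. Any claim that something is new, unique, unknown or untested is made for them only; others in the source may bear on it.

Going by the values given here, in a functional assay on HepG2 cells (Homo sapiens) for antiproliferative activity, read by sulforhodamine B assay, with a stated time of 48 h (a higher number here means a weaker inhibitor, a lower number a stronger inhibitor), compound 1 `COc1ccc(C2C=C(c3cc(OC)c(OC)c(OC)c3)NC(=S)N2)cc1` gives 90 nM, the higher of the two numbers so far, and compound 2 `COc1cccc(C2=NNC(c3ccc(Cl)cc3)C2O)c1` gives 35.3 nM, a gap beyond the scatter. Compound 3 `COc1cc(C2=CC(c3ccc(F)cc3)NC(=S)N2)cc(OC)c1OC` keeps the core of compound 1 but has fluoro in place of methoxy on an aromatic carbon, para to a large group: fluoro in place of methoxy on an aromatic carbon. Among the compounds with values here, no measured pair shows this change, so the estimated no change at the digits printed from compound 1 to compound 3 (within the scatter) is not expected to lie beyond the scatter, in either direction. In this assay, the expected value for compound 3 is 90 nM, with an estimated range of 30 nM to 270 nM.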

Compound 3, half-maximal inhibitory concentration: 61.9 nM
Compound 3: middle estimate off by 1.5-fold (0.16 log units), on the high side; low and high end bracket the measured number.
By their numbers in this assay, from the lowest: compounds 2, 3 and 1 (each within the scatter of the next, the first and the last beyond it).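

In this assay fluoro in place of methoxy on the aromatic carbon para to a large group gives a 1.5-fold lower number from compound 1 to compound 3 (0.16 log units; within the scatter) and so shows that this position accepts either 4-methoxyphenyl or 4-fluorophenyl with no readable shift. The hydrogen-bond acceptor counted on methoxy leaves with that group, yet the number stays within the scatter. No measurement at hand accounts for this step.

As far as these compounds go, whether an amine, a carboxylic acid or a longer alkoxy chain at this position would stay in the same range remains open. So does whether the same change behaves alike on another core.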